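The source may hold more compounds than are shown below. What is called first, only, known or untested is meant among the compounds shown, and "the series" means these compounds.

Series notes on the shared core of compound 1 `CCCc1ccc2[nH]c(=O)c(CN(Cc3ccc(F)cc3)Cc3ccc(C(C)(C)C)cc3)cc2c1`. In a toxicity assay on MDCK cells (Canis lupus familiaris) for cytotoxicity, read by crystal violet staining, with a stated time of 48 h (a lower number here means that less compound is tolerated, a higher number that more compound is tolerated), compound 1 gives 8400 nM. Compound 2 `CCc1ccc2[nH]c(=O)c(CN(Cc3ccc(F)cc3)Cc3ccc(-c4ccccc4)cc3)cc2c1` reaches only a limit in this assay, > 5000 nM. Compound 3 `Cc1ccc2[nH]c(=O)c(CN(Cc3ccc(OC(C)C)cc3)Cc3ccc(C(C)(C)C)cc3)cc2c1` likewise shows only a limit in this assay, > 5000 nM. Compound 3 therefore stands at the edge of the numbers shown, as described by the limit of > 5000 nM in this assay, at which 2 of the 3 values shown sit, and no numerical step separates it from the other two compounds; the values of compound 1 and compound 3 do not allow any order between them to be read.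

Compound 4 `COc1ccc(C(C)N(Cc2ccc(C(C)(C)C)cc2)Cc2cc3cc(C)ccc3[nH]c2=O)cc1` differs from compound 3 in one place: 1-(4-methoxyphenyl)ethyl in place of 4-isopropoxybenzyl on an amine nitrogen. The change keeps one six-membered aromatic ring of carbon only and one hydrogen-bond acceptor on the amine nitrogen, with no net charge. Among the compounds with values here, no measured step between compounds is available, so the size of the change in this assay cannot be taken from a measured pair. For compound 4 a step that the limit leaves unreadable from compound 3 to compound 4 is expected, none beyond the scatter. Compound 4 is estimated at 8000 nM in this assay, between 3000 nM and 20000 nM, with a fair chance that only a limit is reported.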

Compound 4, half-maximal cytotoxic concentration: > 5000 nM
Compound 4: a limit, no number; the forecaster's own chance of this, stated with the estimate: 50%; the middle value is on the limit's open side.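

In this assay compound 4 gives only a limit, > 5000 nM. Within the data shown here, compound 3 also stands at a limit, so no step between compound 3 and compound 4 can be read. Whether the change on the amine nitrogen shifts the tolerated concentration at all remains open: the limit of > 5000 nM in this assay, at which 3 of the 4 values shown sit.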